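This account rests on a few compounds, and the source may have more. Where it says the series, first, only, none or still open, it means among the compounds named here.

Working notes on the series. Among the compounds with values here, in a functional assay on Huh-7 cells (Homo sapiens) for inhibition, read by sulforhodamine B assay, with a stated time of 72 h (on this read-out lower numbers stand for stronger inhibition and higher numbers for weaker inhibition), compound 1 `CC(c1ccc(-c2ccccc2)c(F)c1)c1nnc2n1N=C(c1ccc(OC(F)(F)F)cc1)CS2` gives 8400 nM, compound 3 `CC(c1ccc(-c2ccccc2)c(F)c1)c1nnc2n1N=C(c1ccc(Cl)cc1Cl)CS2` gives 3700 nM, and the step of a 2.3-fold lower number from compound 1 to compound 3 (0.36 log units; beyond the scatter) is the only single-point change measured so far. Compound 2 `COc1ccc2cc(C(C)c3nnc4n3N=C(c3ccc(Cl)cc3Cl)CS4)ccc2c1` gives 10700 nM in this assay, the highest of the three numbers, within the scatter of compound 1 and beyond it against compound 3. Compound 4 `COc1ccc2cc(C(C)c3nnc4n3N=C(c3ccc(Br)cc3)CS4)ccc2c1` differs from compound 2 by 4-bromophenyl in place of 2,4-dichlorophenyl on a carbon with a double bond to nitrogen. The step from compound 1 to compound 3 bears on this change in reverse: there the 2,4-dichlorophenyl gave the lower number, so its loss in favour of a single para-halogenated ring is expected to raise the number modestly, giving an expected step of a 1.5-fold higher number from compound 2 to compound 4 (0.17 log units; within the scatter). Compound 4 is therefore estimated at 16000 nM, with a range of 6000 nM to 40000 nM.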

Compound 4, half-maximal inhibitory concentration: 9300 nM
For compound 4 the middle estimate is 1.7-fold (0.24 log units) above the measured one, within the range that was stated.
By their numbers in this assay, from the lowest: compound 3; then compounds 1, 4 and 2 (each within the scatter of the next).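

In this assay, 4-bromophenyl in place of 2,4-dichlorophenyl on the core of compound 2 gives a 1.2-fold lower number from compound 2 to compound 4 (0.06 log units; within the scatter), so the two rings cannot be told apart at this position on that core. The 2,4-dichlorophenyl therefore shows no edge here, unlike in a 2.3-fold lower number from compound 1 to compound 3 (0.36 log units; beyond the scatter), although that step has a different leaving group and a different remainder of the molecule. Open, as far as these compounds go, is whether an amine or a carboxylic acid on this aryl ring would move the number beyond the scatter. No measured evidence bears on either step.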